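Compound 3 to Compound 4: A Phenyl at the Chain End

This account rests on a few compounds, and the source may have more. Where it says the series, first, only, none or still open, it means among the compounds named here.

Compound 3 `O=c1[nH]c(=O)n([C@H]2C[C@H](O)[C@@H](CO)O2)cc1C#CCCCO` gives 280 ug/mL in a functional assay on L1210 cells (Mus musculus) (a lower number here means a stronger inhibitor, a higher number a weaker inhibitor), the second highest of the three numbers measured. Compound 2 `CCCCCC#Cc1cn([C@H]2C[C@H](O)[C@@H](CO)O2)c(=O)[nH]c1=O` gives 219 ug/mL and compound 1 `CCCC/C=C\c1cn([C@H]2C[C@H](O)[C@@H](CO)O2)c(=O)[nH]c1=O` gives 361 ug/mL; the steps of a 1.6-fold lower number from compound 1 to compound 2 (0.22 log units; within the scatter), a 1.3-fold lower number from compound 1 to compound 3 (0.11 log units; within the scatter) and a 1.3-fold higher number from compound 2 to compound 3 (0.11 log units; within the scatter) all stay within the scatter. Compound 4 `O=c1[nH]c(=O)n([C@H]2C[C@H](O)[C@@H](CO)O2)cc1C#Cc1ccccc1` differs from compound 3 by phenyl in place of 3-hydroxypropyl on a triple-bonded carbon. Among the compounds with values here, the only measured step touching that chain is a 1.3-fold higher number from compound 2 to compound 3 (0.11 log units; within the scatter), which was within the scatter, and no measured step brings in a six-membered aromatic ring, so nothing here points to a shift beyond the scatter. Compound 4 is therefore expected to give about 250 ug/mL, between 100 ug/mL and 600 ug/mL, a step of a 1.1-fold lower number from compound 3 to compound 4 (0.05 log units; within the scatter) that is expected to remain within the scatter.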

Compound 4, concentration for 50% inhibition: 494 ug/mL
For compound 4 the middle estimate is 2.0-fold (0.30 log units) below the measured one; measured number inside the range.
By their numbers in this assay, from the lowest: compounds 2, 3, 1 and 4 (each within the scatter of the next, the first and the last beyond it).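

In this assay, within the data shown here, phenyl in place of pentyl on the triple-bonded carbon gives the only step in this set beyond the scatter, a modest one: a 2.3-fold higher number from compound 2 to compound 4 (0.35 log units; beyond the scatter). Against the other two chains the same ring stays within the scatter, with a 1.8-fold higher number from compound 3 to compound 4 (0.25 log units; within the scatter) and a 1.4-fold higher number from compound 1 to compound 4 (0.14 log units; within the scatter). Nothing measured here offers an explanation for this result.

The compounds shown leave open how a phenyl carrying an amine or a carboxylic acid would read in this position. They also leave open how a longer chain ending in hydroxy would read.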